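This account rests on a few compounds, and the source may have more. Where it says the series, first, only, none or still open, it means among the compounds named here.

Values in a physicochemical assay for solubility, using the shake flask method, in simulated intestinal fluid, measured as kinetic solubility, with a stated time of 2 h, at 25 degrees C, at pH 6.5; a lower number here means a less soluble compound, a higher number a more soluble compound:
- compound 1 `Cc1nc(C(=O)O)c(N)c2c1C(=O)N(Cc1ccccc1)C2=O`: 177000 nM
- compound 2 `Cc1nnc(-c2nc(C)c3c(c2N)C(=O)N(Cc2ccccc2)C3=O)o1`: < 5000 nM, a limit
- compound 3 `Cc1noc(-c2nc(C)c3c(c2N)C(=O)N(Cc2ccccc2)C3=O)n1`: < 5000 nM, a limit

Compound 3 sits at the limit of < 5000 nM in this assay, at which 2 of the 3 values shown sit, so it has a limit and no number. Compound 4 `Cc1nc(C(=O)NC#N)c(N)c2c1C(=O)N(Cc1ccccc1)C2=O` carries cyanocarbamoyl in place of 3-methyl-1,2,4-oxadiazol-5-yl on an aromatic carbon. For the measured compounds named here, two measured steps bear on this change, each swapping the carboxy group for a five-membered aromatic ring: an at least 35-fold lower number from compound 1 to compound 2 (1.54 log units; beyond the scatter) and an at least 35-fold lower number from compound 1 to compound 3 (1.54 log units; beyond the scatter). Both are large. Compound 4 has no ring in this place, as with the carboxy group of compound 1, so a large step to a higher number is expected in this assay. The expected step is an at least 16-fold higher number from compound 3 to compound 4 (1.20 log units; beyond the scatter). For compound 4 the estimate is 80000 nM, with an expected range of 15000 nM to 300000 nM.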

Compound 4, solubility: 185000 nM
The estimate for compound 4 lay 2.3-fold (0.36 log units) below the measured number; measured number inside the range.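

In this assay the open cyanocarbamoyl group in place of either five-membered ring gives a large rise, with an at least 37-fold higher number from compound 3 to compound 4 (1.56 log units; beyond the scatter) and an at least 37-fold higher number from compound 2 to compound 4 (1.56 log units; beyond the scatter) as the two steps. Against the carboxy group, the change gives a 1.0-fold higher number from compound 1 to compound 4 (0.02 log units; within the scatter) and so leaves the number where it was, which shows that carboxy itself is not needed here. Compound 2 and compound 3 each give only a limit, not a number: the limit of < 5000 nM in this assay, at which 2 of the 4 values shown sit.

As far as these compounds go, how far the two ring compounds really lie under that limit stays unknown. From the compounds shown here alone, whether a simple primary amide or a methyl ester here would also keep the number remains open.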